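The source may hold more compounds than are shown below. What is called first, only, known or untested is meant among the compounds shown, and "the series" means these compounds.

Measured so far in an ADME assay on HaCaT cells (Homo sapiens) for inhibition; a lower number here means a stronger inhibitor, a higher number a weaker inhibitor:
compound 1 `COc1cc(-c2cc(C(=O)O)c3ccccc3n2)ccc1OCC(=O)Nc1ccccc1C`: 230000 nM
compound 2 `COc1cc(-c2cc(C(=O)O)c3ccccc3n2)ccc1OCC(=O)Nc1cccc(C(F)(F)F)c1`: 160000 nM

Both compounds share one core and differ only in the aryl group on the amide-type nitrogen. On the numbers shown, compound 2 sits at the low end of this pair, with compound 1 as its only neighbour; the step of a 1.4-fold lower number from compound 1 to compound 2 (0.16 log units; within the scatter) is within the scatter, so no order between the two can be read from this assay.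

Compound 3 `COc1cc(-c2cc(C(=O)O)c3ccccc3n2)ccc1OCC(=O)Nc1ccc(C(F)(F)F)cc1` is the next member. It differs from compound 2 by 4-(trifluoromethyl)phenyl in place of 3-(trifluoromethyl)phenyl on an amide-type nitrogen. For the measured compounds named here, only one measured step bears on the aryl group at this nitrogen, and that step, a 1.4-fold lower number from compound 1 to compound 2 (0.16 log units; within the scatter), exchanged a 2-methylphenyl for a 3-(trifluoromethyl)phenyl without moving the number beyond the scatter. Going by the values given here, no measured pair shows a shift of the trifluoromethyl from one position on the ring to another. The expectation for this assay is therefore no step beyond the scatter, no change at the digits printed from compound 2 to compound 3 (within the scatter). Compound 3 is expected at 160000 nM, with a range from 70000 nM to 350000 nM.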

Compound 3, half-maximal inhibitory concentration in the HaCaT assay: 150000 nM
Beside the measured number, compound 3's estimate is 1.1-fold (0.03 log units) above it; the measured number falls inside the stated range.
By their numbers in the HaCaT assay, from the lowest: compounds 3, 2 and 1 (each within the scatter of the next).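

In the HaCaT assay, compound 2 gives 160000 nM and compound 3 gives 150000 nM; 4-(trifluoromethyl)phenyl in place of 3-(trifluoromethyl)phenyl on the amide-type nitrogen gives a 1.1-fold lower number from compound 2 to compound 3 (0.03 log units; within the scatter) and is the only pair shown in which the trifluoromethyl alone takes another place on the ring, so this exchange has no readable effect on the number. 4-(trifluoromethyl)phenyl in place of 2-methylphenyl at the same nitrogen gives a 1.5-fold lower number from compound 1 to compound 3 (0.19 log units; within the scatter) and so all three aryl groups shown stay within the scatter of one another, with no order among compound 1, compound 2 and compound 3. In a physicochemical assay for lipophilicity, using the shake flask method, in phosphate buffer, measured as octanol-water partition, at pH 7.4 (a higher number here means a more lipophilic compound, a lower number a more polar compound), compound 2 gives 1.3 and compound 3 gives 1.6; the exchange of the two trifluoromethyl-bearing groups gives a number 0.30 log units higher from compound 2 to compound 3 (within the scatter) and so no separation can be read there either.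

No measurement at hand accounts for these flat numbers. Still open, on these data alone, is whether any group on this nitrogen moves the number in the HaCaT assay beyond the scatter, for example a phenyl carrying an amine or a nitrile, or a longer alkyl chain in place of the aryl ring, and whether the carboxylic acid on the shared core has any bearing on the number.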